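The compounds below may be only part of what the source reports. "The series", "measured", "known", "first", "only" and "open" are said of these compounds alone.

Measured so far in a functional assay on HT-29 cells (Homo sapiens) for antiproliferative activity, read by MTT assay; on this read-out higher numbers stand for weaker inhibition and lower numbers for stronger inhibition:
- compound 1 `CN1CCN(c2ccc(Nc3ncc(/N=C/c4ccccc4)c(NC4CCCC4)n3)cc2)CC1` gives 28600 nM
- compound 2 `CN1CCN(c2ccc(Nc3ncc(/N=C/c4ccc(C(F)(F)F)cc4)c(NC4CCCC4)n3)cc2)CC1` gives 80700 nM
- compound 3 `NS(=O)(=O)c1ccc(Nc2ncc(/N=C/c3ccccc3)c(NC3CCCC3)n2)cc1` gives 27000 nM

Compound 3 carries the lowest number of the three, but the step of a 1.1-fold lower number from compound 1 to compound 3 (0.03 log units; within the scatter) lies within the scatter, so compound 3 and compound 1 read as one and the same on this assay. Only compound 2 stands apart; against compound 3 its number is higher by a margin that is beyond the scatter.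

Compound 4 `NS(=O)(=O)c1ccc(Nc2ncc(/N=C/c3ccc(C(F)(F)F)cc3)c(NC3CCCC3)n2)cc1` is to be measured. It differs from compound 3 by trifluoromethyl in place of hydrogen on an aromatic carbon. Going by the values given here, the one measured step that bears on this is a 2.8-fold higher number from compound 1 to compound 2 (0.45 log units; beyond the scatter), the identical change made on compound 1, where the number rose by a modest but real amount. The exchange of the side group itself, a 1.1-fold lower number from compound 1 to compound 3 (0.03 log units; within the scatter), left the number unchanged, which gives no ground to expect the trifluoromethyl step to behave differently on compound 3. The expectation for this assay is therefore a modest rise in number, roughly matching that seen from compound 1 to compound 2, that is a step of a 2.8-fold higher number from compound 3 to compound 4 (0.44 log units; beyond the scatter). Compound 4 is accordingly estimated at 75000 nM, with a range from 35000 nM to 160000 nM.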

Compound 4, half-maximal inhibitory concentration: > 100000 nM
Compound 4: no number, only a limit; the forecaster's own chance of this, stated with the estimate: 10%; at least 1.3-fold (0.12 log units) between middle value and limit.
By their numbers in this assay, from the lowest: compounds 3 and 1 (each within the scatter of the next); then compound 2. At a limit, above all of these: compound 4.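

In this assay compound 4 gives > 100000 nM, which is a limit of the assay and not a number. Trifluoromethyl in place of hydrogen on this aromatic carbon, para to a large group, still gives a rise beyond the scatter in the presence of the sulfamoyl group, an at least 3.7-fold higher number from compound 3 to compound 4 (0.56 log units; beyond the scatter), so the rise is no longer tied to the core of compound 1, and the two steps compare as follows: the same change on two cores in this assay, a 2.8-fold higher number (0.45 log units; beyond the scatter) from compound 1 to compound 2 and an at least 3.7-fold higher number (0.56 log units; beyond the scatter) from compound 3 to compound 4; the limit leaves it open whether they differ. Sulfamoyl in place of 4-methylpiperazin-1-yl, now read with the trifluoromethyl group present, gives an at least 1.2-fold higher number from compound 2 to compound 4 (0.09 log units; that floor lies within the scatter), so this pair shows no separation beyond the scatter, though the true size of the step stays unknown: the same change on two cores in this assay, a 1.1-fold lower number (0.03 log units; within the scatter) from compound 1 to compound 3 and an at least 1.2-fold higher number (0.09 log units; that floor lies within the scatter) from compound 2 to compound 4; the limit leaves it open whether they differ.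

Going by these compounds, how far the number of compound 4 lies past the limit stays open, and the step on this core has only a floor: the limit of > 100000 nM in this assay, at which 1 of the 4 values shown sits. Also open, on these data alone, is whether an amine or a carboxylic acid in place of trifluoromethyl on this aromatic carbon would leave the number where hydrogen has it or move it in either direction.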